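Replacing the ethoxycarbonyl of compound 1 with methoxymethyl

The source may report more compounds than this note shows. Statements on the series, on what has been measured and on what is new or still open speak of the compounds shown alone.

Measured so far:
- compound 1 `CCOC(=O)c1c(C)coc1-c1ccc2c(CC)cccc2c1OC`: 3.8 ug/mL
- compound 2 `CCc1cccc2c(OC(C)=O)c(-c3occ(C)c3COC(C)=O)ccc12`: > 10 ug/mL (a limit of the assay)

For the measured compounds named here, in a functional assay on A549 cells (Homo sapiens) for cytotoxicity, read by MTT assay, with a stated time of 72 h (a lower number here means that less compound is needed, a higher number that more compound is needed for the effect), compound 1 gives 3.8 ug/mL, the only true number in this small set. Compound 2 reads > 10 ug/mL, which is a limit of the assay and not a number. Going by the values given here, compound 1 therefore has no measured neighbour to be ranked against, and no pair of measured compounds differs in one place.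

Compound 3 `CCc1cccc2c(OC)c(-c3occ(C)c3COC)ccc12` is the next to be read in this assay. It keeps the core of compound 1 and carries methoxymethyl in place of ethoxycarbonyl on an aromatic carbon, two ring bonds from the ring oxygen: methoxymethyl in place of ethoxycarbonyl on an aromatic carbon.

Among the compounds with values here, with no measured step to lean on, the expectation rests only on compound 1 at 3.8 ug/mL. A small shift toward needing more compound is expected, possibly no larger than the usual scatter, and the estimated step is a 1.4-fold higher number from compound 1 to compound 3 (0.16 log units; within the scatter). A reading that reaches the limit of the assay remains possible. For compound 3 the estimated value is 5.5 ug/mL, with an expected range from 2 ug/mL to 12 ug/mL.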

Compound 3, concentration for half-maximal effect: > 10 ug/mL
Compound 3: no number, only a limit; the forecaster's own chance of this, stated with the estimate: 25%; middle value at least 1.8-fold (0.25 log units) away from the limit.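

In this assay, for the compounds shown here, methoxymethyl in place of ethoxycarbonyl on this aromatic carbon gives the first readable step: an at least 2.6-fold higher number from compound 1 to compound 3 (0.42 log units; beyond the scatter). On these data alone, compound 3 gives > 10 ug/mL, which is a limit of the assay and not a number, so the step has a lower bound only and its full size remains unknown. Among the groups shown at this place, only the ethoxycarbonyl of compound 1 comes with a true number, and further changes that call for more compound may also read only as limits: the limit of > 10 ug/mL in this assay, at which 2 of the 3 values shown sit.

The step removes the carbonyl and shortens the group in one move, so the compounds shown cannot tell which of the two goes with the higher number. A carboxylic acid, a primary amide or a longer chain such as butoxycarbonyl on this same carbon would separate the two, and would show whether any group here can match or improve on the reading of compound 1.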